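Methoxy in Place of Chloro: Expecting Little Movement

The compounds below may be only part of what the source reports. "The series", "measured", "known", "first", "only" and "open" are said of these compounds alone.

Of the compounds shown here, three built on one shared core have been measured. Compound 1 `CC1=C(/C=C/C(=O)/C=C/c2ccccc2)C(C)(C)CCC1` carries an aromatic ring with no substituent, and in a functional assay on PC-3 cells (Homo sapiens) for cytotoxicity, read by sulforhodamine B assay, with a stated time of 48 h (on this read-out higher numbers stand for weaker inhibition and lower numbers for stronger inhibition), compound 1 gives 12400 nM. Compound 2 `CC1=C(/C=C/C(=O)/C=C/c2ccc(F)cc2)C(C)(C)CCC1` adds a fluoro to that ring, and in this assay compound 2 gives 8200 nM. Compound 3 `CC1=C(/C=C/C(=O)/C=C/c2ccccc2Cl)C(C)(C)CCC1` adds a chloro instead, and in this assay compound 3 gives 11300 nM. None of the three steps between them reaches beyond the usual scatter: a 1.5-fold lower number from compound 1 to compound 2 (0.18 log units; within the scatter), a 1.1-fold lower number from compound 1 to compound 3 (0.04 log units; within the scatter) and a 1.4-fold higher number from compound 2 to compound 3 (0.14 log units; within the scatter). Compound 3 is therefore indistinguishable, within the scatter, from both of its neighbours.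

Compound 4 `COc1ccccc1/C=C/C(=O)/C=C/C1=C(C)CCCC1(C)C` follows from compound 3 by one change: methoxy in place of chloro on an aromatic carbon. The step that bears most directly on it is the one that introduced the chloro, from compound 1 to compound 3, and it stayed within the scatter; the two other ring changes did the same. Reversing the chloro and placing a methoxy there is expected to behave alike, so the expected step in this assay is a 1.1-fold lower number from compound 3 to compound 4 (0.05 log units; within the scatter), that is, no change beyond the scatter. For compound 4 the estimate in this assay is 10000 nM, with a range from 5000 nM to 20000 nM.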

Compound 4, half-maximal inhibitory concentration: 14200 nM
Beside the measured number, compound 4's estimate is 1.4-fold (0.15 log units) below it; low and high end bracket the measured number.
By their numbers in this assay, from the lowest: compounds 2, 3, 1 and 4 (each within the scatter of the next).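

In this assay this aromatic carbon, ortho to a large group, can now be compared across three occupants: hydrogen, chloro and methoxy. Methoxy in place of chloro gives a 1.3-fold higher number from compound 3 to compound 4 (0.10 log units; within the scatter) and methoxy in place of hydrogen gives a 1.1-fold higher number from compound 1 to compound 4 (0.06 log units; within the scatter) so both steps stay within the scatter, even though methoxy brings two heavy atoms and a hydrogen-bond acceptor where chloro brings one heavy atom and no acceptor. At this position, then, the number does not separate these three occupants, and no measurement at hand offers an explanation for that.

Still open, going by these compounds, is whether a group of a different kind on this same carbon, such as an amine or a carboxylic acid, would carry the number beyond the scatter. Also open, on these data alone, is whether methoxy on another carbon of the aromatic ring would stay within the scatter of compound 1 in the same way, since the one position tested here cannot speak for the others.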